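Chloro in Place of Ethyl: Expected Shift in Inhibition

A few compounds are considered here, and "the series" means these few. Any claim that something is new, unique, unknown or untested is made for them only; others in the source may bear on it.

Compound 1: `CCc1ccc(-n2nc(-c3ccccc3)nc2CNc2ccc(C(=O)NO)cc2)cc1` — 38.3%
Compound 2: `Cc1ccccc1-c1nc(CNc2ccc(C(=O)NO)cc2)n(-c2ccccc2)n1` — 53.2%
Compound 3: `O=C(NO)c1ccc(NCc2nc(-c3ccccn3)nn2-c2ccccc2)cc1` — 58.6%

In an assay on Sf9 cells for inhibition of protein deacetylase HDAC6 (Homo sapiens), read by fluorescence, with a stated time of 40 min, tested at 100 nM (a lower number here means less inhibition, a higher number more inhibition at the concentration tested (going by the name of the read-out)), compound 1 gives 38.3%, the lowest of the three numbers. Its nearest neighbour, compound 2, gives 53.2%, and compound 3 gives 58.6%; both stand beyond the scatter above compound 1. Compound 4 `O=C(NO)c1ccc(NCc2nc(-c3ccccc3)nn2-c2ccc(Cl)cc2)cc1` differs from compound 1 in one place: chloro in place of ethyl on an aromatic carbon. Going by the values given here, the single measured step, a number 5.4 percentage points higher from compound 2 to compound 3 (within the scatter), alters a different part of the shared core and lies within the scatter, so it offers no direct guide. Among the compounds with values here, no measured pair bears on chloro replacing ethyl at this site. The author therefore expects only a modest step, a number 5.7 percentage points higher from compound 1 to compound 4 (within the scatter), with wide uncertainty. Compound 4 is estimated at 44%, within a range from 24% to 64%.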

Compound 4, a percentage reported as inhibition, at one concentration (the size of the read-out at that concentration, not a potency): 55.4%
The estimate for compound 4 lay 11.4 percentage points below the measured number; low and high end bracket the measured number.
By their numbers in this assay, from the lowest: compound 1; then compounds 2, 4 and 3 (each within the scatter of the next).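

In this assay, 4-chlorophenyl in place of 4-ethylphenyl gives a number 17.1 percentage points higher from compound 1 to compound 4 (beyond the scatter) on the shared core, so this site, para to a large group, responds to a change of one group. The low number of compound 1 thus goes with its ethyl group rather than with the core alone. Nothing at hand gives a measured reason for this step.

From the compounds shown here alone, how an amine, a carboxylic acid or a longer chain would read at this place remains open. So does whether the same change would carry over to the cores of compound 2 and compound 3.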